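This account rests on a few compounds, and the source may have more. Where it says the series, first, only, none or still open, it means among the compounds named here.

Values in a physicochemical assay for lipophilicity; on this read-out lower numbers stand for lower lipophilicity and higher numbers for higher lipophilicity:
- Compound 1 `CCN(CC)CCCS(=O)(=O)c1ccc2nc(NC(=O)NC(=O)c3cc(-n4cccn4)ccc3Cl)sc2c1`: 2.1
- Compound 2 `CN1CCN(CCCS(=O)(=O)c2ccc3nc(NC(=O)NC(=O)c4cc(-n5cccn5)ccc4Cl)sc3c2)CC1`: 2
- Compound 3 `CN1CCC(S(=O)(=O)c2ccc3nc(NC(=O)NC(=O)c4cc(-n5cccn5)ccc4Cl)sc3c2)CC1`: 2.5

The steps out of compound 1 place it among the three: a number 0.10 log units lower from compound 1 to compound 2 (within the scatter), and a number 0.40 log units higher from compound 1 to compound 3 (beyond the scatter). Compound 4 `CCN(CC)CCCS(=O)(=O)c1ccc2nc(NC(=O)NC(=O)c3ccccc3Cl)sc2c1` differs from compound 1 by hydrogen in place of 1H-pyrazol-1-yl on an aromatic carbon. Among the measured compounds shown here, no measured step tests this change. Those above, and a number 0.50 log units higher from compound 2 to compound 3 (beyond the scatter), all alter the group on the sulfonyl sulfur, and they show only what size of step occurs here. With a whole ring leaving, a modest fall is expected, and the estimate is a number 0.40 log units lower from compound 1 to compound 4 (beyond the scatter). Compound 4 is expected at about 1.7, with an estimated range of 1.2 to 2.2.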

Compound 4, distribution coefficient: 1.7
The estimate for compound 4 equals the measured number at the digits printed; measured number inside the range.
By their numbers in this assay, from the lowest: compounds 4, 2 and 1 (each within the scatter of the next, the first and the last beyond it); then compound 3.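

Every earlier step altered the group on the sulfonyl sulfur, whereas this one changes an aromatic carbon of the ring that carries the chloro group. In this assay, hydrogen in place of 1H-pyrazol-1-yl gives a number 0.40 log units lower from compound 1 to compound 4 (beyond the scatter), so a change at this position also moves the read-out beyond the scatter. No measurement here explains this step.

On these data alone, whether a methoxy group or an amine on this carbon would fall nearer compound 4 or compound 1 remains open. So does whether losing 1H-pyrazol-1-yl gives a step of similar size when 1-methylpiperidin-4-yl sits on the sulfonyl sulfur, as in compound 3.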